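Working notes: from compound 3 to compound 4

This account rests on a few compounds, and the source may have more. Where it says the series, first, only, none or still open, it means among the compounds named here.

Values in a functional assay on DU-145 cells (Homo sapiens) for inhibition, read by trypan blue exclusion, with a stated time of 96 h (a higher number here means a weaker inhibitor of growth, a lower number a stronger inhibitor of growth), are as follows:
- compound 1 `O=C(O)c1ccc(C(=O)/C(=C\c2ccc(Br)cc2)SCc2ccc(F)cc2)cc1` gives > 100000 nM as a limit
- compound 2 `O=C(/C(=C\c1c[nH]c2ccccc12)SCc1ccc(F)cc1)c1ccc(Cl)cc1` gives 1000 nM as a number
- compound 3 `Cc1ccc(/C=C(/SCc2ccc(F)cc2)C(=O)c2ccc(Cl)cc2)s1` gives > 100000 nM as a limit

Compound 3 stands with > 100000 nM as its reading, which is a limit and not a number. The series as a whole sits largely at that end of the scale, with the limit of > 100000 nM in this assay, at which 2 of the 3 values shown sit, as the summary.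

Compound 4 `O=C(/C(=C\c1ccc(Br)cc1)SCc1ccc(F)cc1)c1ccc(Cl)cc1` is still unmeasured. The change from compound 3 to compound 4 is 4-bromophenyl in place of 5-methylthiophen-2-yl on a double-bonded chain carbon bound to a double-bonded chain carbon and it puts 4-bromophenyl in place of 5-methylthiophen-2-yl on a double-bonded chain carbon bound to a double-bonded chain carbon.

Within the data shown here, one measured step bears on this place: an at least 100-fold higher number from compound 2 to compound 3 (2.00 log units; beyond the scatter) is large and beyond the scatter, so the group there can matter greatly in this assay for this series. That step does not involve 4-bromophenyl. Compound 4 shares 4-bromophenyl with compound 1, though not the rest of the structure. Compound 1 gives > 100000 nM and that is a limit only.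

Among the measured compounds shown here, the expectation of a lower number rests on compound 2 at 1000 nM as the one measured number. A further limit remains possible for compound 4. The expected step is an at least 10-fold lower number from compound 3 to compound 4 (1.00 log units; beyond the scatter) in the direction of stronger inhibition of growth. Compound 4 is estimated at 10000 nM within an expected range from 1000 nM to 100000 nM as the working figure.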

Compound 4, concentration for 50% growth inhibition: 9000 nM
Compound 4: the middle estimate sits 1.1-fold (0.05 log units) above what was measured, within the range that was stated.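

In this assay, measurable inhibition of growth at the place on a double-bonded chain carbon bound to a double-bonded chain carbon is not confined to 1H-indol-3-yl: an at least 11-fold lower number from compound 3 to compound 4 (1.04 log units; beyond the scatter) shows that 4-bromophenyl also gives a numerical reading, in a step that starts from a limit. Even so, the two groups do not read alike, as a 9.0-fold higher number from compound 2 to compound 4 (0.95 log units; beyond the scatter) puts 4-bromophenyl on the weaker side of 1H-indol-3-yl in this series. The 4-bromophenyl group is also not enough by itself: an at least 11-fold lower number from compound 1 to compound 4 (1.04 log units; beyond the scatter) is a step from a limit, with chloro in place of carboxy on an aromatic carbon, so a second place in the series matters greatly in this assay.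

Going by these compounds, whether a plain phenyl or a 4-aminophenyl group at the first place would read with compound 2 or with compound 4 stays open, as does whether an amine or a methoxy group in place of chloro would hold the reading of compound 4. Limits also remain common in the set, and they fix no exact size for any step from compound 1 or compound 3: the limit of > 100000 nM in this assay, at which 2 of the 4 values shown sit.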